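A few compounds are considered here, and "the series" means these few. Any claim that something is new, unique, unknown or untested is made for them only; others in the source may bear on it.

Of the compounds shown here, three sharing one core have been measured in a functional assay with Mus musculus as the target; on this read-out higher numbers stand for an effect only at larger amounts of compound and lower numbers for an effect already at smaller amounts. Compound 1 `Nc1nc(O)c2c(n1)n(C1OC(CO)[C@@H](O)[C@H]1O)c(=O)n2C/C=C/c1ccccc1` carries a 2-phenylethenyl group on a saturated chain carbon bound to an aromatic nitrogen, and in this assay compound 1 gives 4 uM. Compound 2 `CCOC(=O)Cn1c(=O)n(C2OC(CO)[C@@H](O)[C@H]2O)c2nc(N)nc(O)c21` has an ethoxycarbonyl group at that place, and compound 2 gives 630 uM. Compound 3 `CCCCCCn1c(=O)n(C2OC(CO)[C@@H](O)[C@H]2O)c2nc(N)nc(O)c21` has a pentyl group there, and compound 3 gives 600 uM. On these numbers compound 3 stands second highest of the three, though within the scatter of compound 2 and far from compound 1: a 160-fold higher number from compound 1 to compound 2 (2.20 log units; beyond the scatter), a 150-fold higher number from compound 1 to compound 3 (2.18 log units; beyond the scatter), while a 1.1-fold lower number from compound 2 to compound 3 (0.02 log units; within the scatter).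

Compound 4 `Cn1c(=O)n(C2OC(CO)[C@@H](O)[C@H]2O)c2nc(N)nc(O)c21` is compound 3 with hydrogen in place of pentyl on a saturated chain carbon bound to an aromatic nitrogen. Among the compounds with values here, no measured step removes a chain at this place outright. The nearest guides are the two large steps away from compound 1, which show how much the 2-phenylethenyl group matters, and the step between compound 2 and compound 3, which shows that two quite different groups give about the same number. The pentyl group thus appears to add little, and compound 4 is expected to stay in the same weak region, with a 1.3-fold higher number from compound 3 to compound 4 (0.12 log units; within the scatter) expected to fall within the scatter or modestly upward. The estimate for compound 4 is 800 uM, with a range from 200 uM to 3000 uM.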

Compound 4, concentration for half-maximal effect: 120 uM
For compound 4 the middle estimate is 6.7-fold (0.82 log units) above the measured one; measured number below the stated range.
By their numbers in this assay, from the lowest: compound 1; then compound 4; then compounds 3 and 2 (each within the scatter of the next).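

The new result shows that this position does not simply tolerate any group: with only methyl left on the aromatic nitrogen, compound 4 separates from the two weak compounds in this assay (a 5.0-fold lower number from compound 3 to compound 4 (0.70 log units; beyond the scatter); a 5.3-fold lower number from compound 2 to compound 4 (0.72 log units; beyond the scatter)). Compounds 2 and 3 therefore share a higher number than this smaller group gives, even though hexyl and the ethoxycarbonyl-bearing chain differ so much from each other. Compound 1 goes against any rule that a larger group here always raises the number (a 30-fold higher number from compound 1 to compound 4 (1.48 log units; beyond the scatter)), and nothing available here explains either direction of change.

The compounds shown leave open which part of the 2-phenylethenyl group goes with the low number of compound 1, the phenyl ring or the double bond, and a benzyl or 3-phenylpropyl group at this place would help to separate the two. They also leave open how a chain of intermediate length, such as propyl, or a chain ending in an amine or a carboxylic acid would fall on this scale.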